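This account rests on a few compounds, and the source may have more. Where it says the series, first, only, none or still open, it means among the compounds named here.

Of the compounds shown here, three sharing one core have been read in a physicochemical assay for solubility, read by spectrophotometry, in phosphate buffer, with a stated time of 18 h, at pH 7.4 (on this read-out higher numbers stand for higher solubility and lower numbers for lower solubility), and they differ only in the group on an aromatic carbon ortho to a large group. Compound 1 `CCc1ccc(-c2nc3c(c(C)nn3-c3ccccc3)c(-c3ccccc3S(C)(=O)=O)c2C#N)cc1`, with methylsulfonyl, gives 2200 nM. Compound 2 `CCc1ccc(-c2nc3c(c(C)nn3-c3ccccc3)c(-c3ccccc3C(=O)O)c2C#N)cc1`, with carboxy, gives 33000 nM. Compound 3 `CCc1ccc(-c2nc3c(c(C)nn3-c3ccccc3)c(-c3ccccc3C(F)(F)F)c2C#N)cc1`, with trifluoromethyl, gives 11000 nM, which makes it the second highest of the three, under compound 2 and over compound 1.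

The next compound, compound 4 `CCc1ccc(-c2nc3c(c(C)nn3-c3ccccc3)c(-c3ccccc3OC(F)(F)F)c2C#N)cc1`, carries trifluoromethoxy in place of trifluoromethyl on that aromatic carbon: trifluoromethoxy in place of trifluoromethyl on an aromatic carbon. Within the data shown here, three measured steps bear on this change, all at the same place and all beyond the scatter: a 15-fold higher number from compound 1 to compound 2 (1.18 log units; beyond the scatter) is large, while a 5.0-fold higher number from compound 1 to compound 3 (0.70 log units; beyond the scatter) and a 3.0-fold lower number from compound 2 to compound 3 (0.48 log units; beyond the scatter) are modest. None of them exchanges these two groups, so they show only that this place can move the read-out.

Starting from compound 3 at 11000 nM, a small drift to a lower number is expected in this assay, most likely not beyond the scatter. The expected step is a 1.6-fold lower number from compound 3 to compound 4 (0.20 log units; within the scatter). For compound 4 the estimated value is 7000 nM, with an expected range from 2500 nM to 16000 nM.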

Compound 4, solubility: 9900 nM
Compound 4: the middle estimate sits 1.4-fold (0.15 log units) below what was measured; the measured number falls inside the stated range.
By their numbers in this assay, from the lowest: compound 1; then compounds 4 and 3 (each within the scatter of the next); then compound 2.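

Among these compounds, the exchange of trifluoromethyl for trifluoromethoxy, which none of the earlier pairs tested directly, reads a 1.1-fold lower number from compound 3 to compound 4 (0.05 log units; within the scatter), so at this aromatic carbon the two groups cannot be told apart in this assay. Set against the other two groups, the trifluoromethoxy compound keeps the place that the trifluoromethyl compound held, with a 3.3-fold lower number from compound 2 to compound 4 (0.52 log units; beyond the scatter) and a 4.5-fold higher number from compound 1 to compound 4 (0.65 log units; beyond the scatter), both modest but beyond the scatter, so the carboxy and methylsulfonyl compounds still lie on either side of this pair. No measurement shown offers any reason for these numbers.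

The compounds shown leave open how other groups on this aromatic carbon would read, such as methoxy, a chlorine atom or an amine, and whether any of them would come near the carboxy compound or fall to the level of the methylsulfonyl compound. They also leave open whether the exchange of trifluoromethyl for trifluoromethoxy would read the same way on a core carrying a longer chain in place of the ethyl group, or an amide in place of the nitrile.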